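Repeating the methyl step on the second core

This account rests on a few compounds, and the source may have more. Where it says the series, first, only, none or still open, it means among the compounds named here.

Measured in a functional assay on MCF7 cells (Homo sapiens) for inhibition, read by colorimetric assay and MTT assay, with a stated time of 72 h; on this read-out lower numbers stand for stronger inhibition and higher numbers for weaker inhibition:
compound 1 `COc1ccc(C(=O)NNC(=S)Nc2csc(-c3ccccc3)c2)cc1` gives 32000 nM
compound 2 `COc1ccc(C(=O)NNC(=S)Nc2csc(-c3ccc(C)cc3)c2)cc1` gives 5000 nM
compound 3 `COc1ccc(C(=O)NNC(=S)Nc2csc(-c3ccccc3)c2)cc1OC` gives 21000 nM

Compound 4 `COc1ccc(C(=O)NNC(=S)Nc2csc(-c3ccc(C)cc3)c2)cc1OC` is not yet measured in this assay.

The two cores differ by methoxy in place of hydrogen on an aromatic carbon; in this assay that gives a 1.5-fold lower number from compound 1 to compound 3 (0.18 log units; within the scatter), so compounds 1 and 3 sit together. Going by the values given here, the change from compound 1 to compound 2 is methyl in place of hydrogen on an aromatic carbon, and it gives a 6.4-fold lower number from compound 1 to compound 2 (0.81 log units; beyond the scatter), the one step in the set that stands out. The change from compound 3 to compound 4 is methyl in place of hydrogen on an aromatic carbon; its place is described in the same words as for compound 2, so this is the same change, now made on the core of compound 3. Among the compounds with values here, only one measurement of this change exists, and both cores lie within the scatter of each other, so no reason is seen for it to behave differently on the second core. Within the data shown here, compound 4 is expected to show a step of about the earlier size, a 5.3-fold lower number from compound 3 to compound 4 (0.72 log units; beyond the scatter), because a 6.4-fold lower number from compound 1 to compound 2 (0.81 log units; beyond the scatter) is the only measure of this change. The starting point is compound 3 at 21000 nM. Compound 4 is therefore estimated at 4000 nM, expected to fall between 1500 nM and 12000 nM.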

Compound 4, half-maximal inhibitory concentration: 11000 nM
Compound 4: the middle estimate sits 2.8-fold (0.44 log units) below what was measured; measured number inside the range.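

In this assay, phenyl to 4-methylphenyl on the core of compound 3 gives a 1.9-fold lower number from compound 3 to compound 4 (0.28 log units; within the scatter), and the same change does not carry the same size across the two cores: the same change on two cores in this assay, a 6.4-fold lower number (0.81 log units; beyond the scatter) from compound 1 to compound 2 and a 1.9-fold lower number (0.28 log units; within the scatter) from compound 3 to compound 4, 3.4-fold (0.53 log units) apart, beyond the scatter of two such steps. Seen from the other direction, methoxy in place of hydrogen gives a 2.2-fold higher number from compound 2 to compound 4 (0.34 log units; beyond the scatter), so that change also depends on the core that receives it: the same change on two cores in this assay, a 1.5-fold lower number (0.18 log units; within the scatter) from compound 1 to compound 3 and a 2.2-fold higher number (0.34 log units; beyond the scatter) from compound 2 to compound 4, 3.4-fold (0.53 log units) apart, beyond the scatter of two such steps. Both gaps rest on the same four compounds and are therefore one observation seen from two sides; this shows that neither step can be carried unchanged between these two cores, but it does not show why, or how either change would behave on any other core.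

The compounds shown leave open whether an amine or a chlorine in place of the methyl would also depend on the core. Also open, as far as these compounds go, is whether a longer chain, such as ethyl, would follow compound 2 or compound 4.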